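A few compounds are considered here, and "the series" means these few. Any claim that something is new, unique, unknown or untested is made for them only; others in the source may bear on it.

Among the compounds with values here, compound 2 `COc1cccc(Oc2c(NS(=O)(=O)c3ccc(C(C)(C)C)cc3)ncnc2OCCOc2nccc(C)n2)c1` holds the lowest of the two numbers so far in an assay on cells (Endothelial cell) for binding affinity to Endothelin-1 receptor (Sus scrofa) (a higher number here means a weaker inhibitor, a lower number a stronger inhibitor), at 39.4 nM; compound 1 `COCCOc1ncnc(NS(=O)(=O)c2ccc(C(C)(C)C)cc2)c1Oc1cccc(OC)c1` sits higher in this assay at 92 nM, and the step of a 2.3-fold lower number from compound 1 to compound 2 (0.37 log units; beyond the scatter) is modest. Compound 3 `COc1cccc(Oc2c(NCCOc3ncccn3)ncnc2NS(=O)(=O)c2ccc(C(C)(C)C)cc2)c1` has not yet been measured. It differs from compound 2 in one place: (2-((pyrimidin-2-yl)oxy)ethyl)amino in place of 2-((4-methylpyrimidin-2-yl)oxy)ethoxy on an aromatic carbon. Within the data shown here, only one measured step touches the same side chain, namely a 2.3-fold lower number from compound 1 to compound 2 (0.37 log units; beyond the scatter), where a 4-methylpyrimidin-2-yl replaced a methyl; no measured pair tests an amino in place of the ether-type attachment, nor the loss of the methyl on the pyrimidine. A step no larger than that one is therefore expected for compound 3, most likely within the scatter and in no firm direction. Compound 3 is estimated at 50 nM, with a range of 20 nM to 130 nM, which would be an expected step of a 1.3-fold higher number from compound 2 to compound 3 (0.10 log units; within the scatter) in this assay.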

Compound 3, half-maximal inhibitory concentration: 6.2 nM
For compound 3 the middle estimate is 8.1-fold (0.91 log units) above the measured one, outside the stated range (below it).
By their numbers in this assay, from the lowest: compound 3; then compound 2; then compound 1.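

The side chain on this aromatic carbon turns out to have more room to move the number in this assay than the ether-linked series suggested: (2-((pyrimidin-2-yl)oxy)ethyl)amino in place of 2-((4-methylpyrimidin-2-yl)oxy)ethoxy gives a 6.4-fold lower number from compound 2 to compound 3 (0.80 log units; beyond the scatter). Against the simple 2-methoxyethoxy chain, the same group gives a 15-fold lower number from compound 1 to compound 3 (1.17 log units; beyond the scatter), so the 4-methyl on the pyrimidine is not needed for a low number, and the entering group carries one hydrogen-bond donor where the leaving group has none. No measurement here explains the gain.

On these data alone, the step changes the linking atom and removes the methyl together, so the share of each stays open. A (2-((4-methylpyrimidin-2-yl)oxy)ethyl)amino chain, a 2-((pyrimidin-2-yl)oxy)ethoxy chain or an N-methylamino link would separate them.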